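This account rests on a few compounds, and the source may have more. Where it says the series, first, only, none or still open, it means among the compounds named here.

Measured series:
- compound 1 `FC(F)(F)c1cccc(-c2nnc(-c3cccnc3NCc3ccncc3)[nH]2)c1`: > 10000 nM
- compound 2 `c1cncc(CNc2ncccc2-c2nnc(Nc3ccc4c(c3)OCCO4)o2)c1`: 13 nM
- compound 3 `c1ccc(-c2nnc(Nc3ccc4c(c3)OCCO4)o2)c(NCc2ccncc2)c1`: 9 nM

In a functional assay on A-431 cells (Homo sapiens), read by propidium iodide staining, with a stated time of 24 h (on this read-out lower numbers stand for an effect already at smaller amounts and higher numbers for an effect only at larger amounts of compound), compound 2 gives 13 nM and compound 3 gives 9 nM, so these two values lie within the scatter of each other. Compound 1 stands at > 10000 nM, which is a limit of the assay and not a number.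

The next compound to be measured is compound 4 `c1cnc(NCc2ccc3ncccc3c2)c(-c2nnc(Nc3ccc4c(c3)OCCO4)o2)c1`. It carries quinolin-6-yl in place of the pyridin-3-yl of compound 2, on a saturated chain carbon bound to a nitrogen on an aromatic ring: quinolin-6-yl in place of pyridin-3-yl on a saturated chain carbon bound to a nitrogen on an aromatic ring.

Among the compounds with values here, no measured single-place step is available as a guide in this assay, so the expectation is only loosely anchored. It rests on compound 2 at 13 nM and compound 3 at 9 nM, which sit close together. A moderate rise in the number is expected, slightly beyond the scatter, and the estimated step is a 2.7-fold higher number from compound 2 to compound 4 (0.43 log units; beyond the scatter).

For compound 4 the expected value is 35 nM, with an estimated range of 6 nM to 300 nM.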

Compound 4, half-maximal effective concentration: 18 nM
The estimate for compound 4 lay 1.9-fold (0.29 log units) above the measured number, and the stated range covers the measured number.
By their numbers in this assay, from the lowest: compounds 3, 2 and 4 (each within the scatter of the next). At a limit, above all of these: compound 1.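

Replacing pyridin-3-yl with quinolin-6-yl on a saturated chain carbon bound to a nitrogen on an aromatic ring gives a 1.4-fold higher number from compound 2 to compound 4 (0.14 log units; within the scatter) in this assay, the first single-place step read in this series. At this place, a group of 10 heavy atoms with two six-membered aromatic rings therefore stands level with one of 6 heavy atoms and a single ring, with no change beyond the scatter. No measurement shown bears on why this is so.

On these data alone, it remains open whether this place also accepts a non-aromatic group, such as a piperidine or a plain alkyl chain. As far as these compounds go, it also remains open whether quinolin-6-yl would read the same on the core of compound 3.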